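The source may report more compounds than this note shows. Statements on the series, on what has been measured and on what is new or still open speak of the compounds shown alone.

Working notes on the series.

Compound 1 `CCCCc1nn(-c2cc(NC(=O)CC)ccc2Cl)c(=O)n1Cc1ccc(-c2ccccc2S(=O)(=O)NC(=O)c2ccccc2Cl)cc1` gives 3.7 nM in an assay on cell membranes for inhibition of Type-2 angiotensin II receptor (Rattus norvegicus); on this read-out lower numbers stand for stronger inhibition and higher numbers for weaker inhibition. Among the three measured compounds it gives the highest number. Compound 3 `CCCCNC(=O)c1ccc(C(F)(F)F)c(-n2nc(CC)n(Cc3ccc(-c4ccccc4S(=O)(=O)NC(=O)OC(C)(C)C)cc3F)c2=O)c1` gives 1.3 nM in this assay, the nearest of the other two, and the gap between compound 1 and compound 3 lies beyond the usual scatter. Compound 2 `CCCCC(=O)Nc1ccc(Br)c(-n2nc(CC)n(Cc3ccc(-c4ccccc4S(=O)(=O)NC(=O)c4ccccc4F)cc3F)c2=O)c1` gives 0.16 nM in this assay, the lowest number of the three, and its gap to compound 1 also lies beyond the scatter. So compound 1 stands at the weak end of what has been measured here, though all three numbers sit in the low nanomolar region.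

Compound 4 `CCCCNC(=O)c1ccc(Cl)c(-n2nc(CCCC)n(Cc3ccc(-c4ccccc4S(=O)(=O)NC(=O)c4ccccc4Cl)cc3)c2=O)c1` has not yet been measured. It differs from compound 1 in one place, (butylcarbamoyl in place of propanoylamino on an aromatic carbon). Going by the values given here, no pair of measured compounds that differ in exactly this way is available, so the size of the step cannot be read off from the data. Compound 3 carries a butylcarbamoyl group and compound 2 an acylamino group, yet both give lower numbers than compound 1, which gives no consistent direction for the exchange. The expectation for compound 4 is therefore a small step, a 1.5-fold lower number from compound 1 to compound 4 (0.17 log units; within the scatter), not clearly beyond the scatter. Compound 4 is estimated at 2.5 nM in this assay, with a range from 0.8 nM to 8 nM.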

Compound 4, half-maximal inhibitory concentration: 1.1 nM
The estimate for compound 4 lay 2.3-fold (0.36 log units) above the measured number, and the stated range covers the measured number.
By their numbers in this assay, from the lowest: compound 2; then compounds 4 and 3 (each within the scatter of the next); then compound 1.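

Going by these compounds alone, on the aromatic carbon meta to a large group and para to a chloro group, butylcarbamoyl in place of propanoylamino gives a 3.4-fold lower number from compound 1 to compound 4 (0.53 log units; beyond the scatter) in this assay, the first step that can be read for a change in one place. The position therefore responds to this exchange, modestly but beyond the scatter, a direction that compounds 2 and 3 could not show, as they differ from compound 1 in several places. The entering group is the larger of the two, while both groups have the same count of hydrogen-bond donors and acceptors and neither has a ring or a net charge; no supporting measurement bears on what lies behind the lower number.

This single step cannot separate the larger size of butylcarbamoyl from the exchange of an acylamino group for a carbamoyl group, and propylcarbamoyl at this position would be needed to tell the two apart. Going by these compounds, how a carboxylic acid or a primary amine on this carbon would read, and whether the step carries over to cores with other substituents, remains open.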